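A few compounds are considered here, and "the series" means these few. Any claim that something is new, unique, unknown or untested is made for them only; others in the source may bear on it.

Working notes on the series. Compound 2 `O=S(=O)(CCC(F)=C(F)F)c1nc2ccccc2[nH]1` carries the bare core and compound 1 `O=S(=O)(CCC(F)=C(F)F)c1nc2ccc(OC(F)F)cc2[nH]1` carries the same core with one added group. In a functional assay on MCF7 cells (Homo sapiens) for cytotoxicity, read by MTT assay, with a stated time of 48 h (on this read-out lower numbers stand for stronger inhibition and higher numbers for weaker inhibition), compound 2 gives only a limit, > 120000 nM. In this assay compound 1 likewise gives only a limit, > 120000 nM. The change between them is difluoromethoxy in place of hydrogen on an aromatic carbon; the step that the two limits leave unreadable from compound 2 to compound 1 cannot be sized, because of the limit of > 120000 nM in this assay, at which 3 of the 3 values shown sit. Compound 3 `FC(F)=C(F)CCSc1nc2ccccc2[nH]1` has another core; how the two cores differ is not broken down here. In this assay compound 3 gives only a limit, > 120000 nM. Compound 4 `FC(F)=C(F)CCSc1nc2ccc(OC(F)F)cc2[nH]1` is not yet measured and differs from compound 3 by difluoromethoxy in place of hydrogen on an aromatic carbon, the same change as that made from compound 2 to compound 1. For compound 4 the step that the limit leaves unreadable from compound 3 to compound 4 is expected to be small, because of the limit of > 120000 nM in this assay, at which 3 of the 3 values shown sit. Compound 4 is therefore expected to give 200000 nM, within 100000 nM to 1000000 nM, most likely reported again only as a limit.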

Compound 4, half-maximal inhibitory concentration: > 120000 nM
Compound 4: only a limit was reported (the forecaster's own chance of this, stated with the estimate: 90%); the middle value is on the limit's open side.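

For the compounds shown here, compound 3 and compound 4 both give only a limit in this assay, so no step between them can be read: the limit of > 120000 nM in this assay, at which 4 of the 4 values shown sit. The compounds shown leave open whether difluoromethoxy in place of hydrogen on an aromatic carbon changes cytotoxicity at all.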